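This account rests on a few compounds, and the source may have more. Where it says the series, first, only, none or still open, it means among the compounds named here.

Compound 2, `c1ccc(OCc2nc3c(OCCCN4CCCCC4)cccc3n2CCCC2CCNCC2)cc1`, gives 4.5 nM in an in vitro assay on AV12 cells for binding affinity to Neuropeptide Y receptor type 1 (Homo sapiens) (a higher number here means a weaker inhibitor, a lower number a stronger inhibitor), the higher of the two numbers at hand. Compound 1, `c1ccc(OCc2nc3c(OCCCN4CCCCC4)cccc3n2CCCC2CCN(CCCN3CCCCC3)CC2)cc1`, gives 0.106 nM in this assay. For the measured compounds named here, the single measured step, a 42-fold higher number from compound 1 to compound 2 (1.63 log units; beyond the scatter), shows how much of the affinity rests on a substituent at that ring nitrogen. Compound 3, `C=CCN1CCC(CCCn2c(COc3ccccc3)nc3c(OCCCN4CCCCC4)cccc32)CC1`, differs from compound 2 by allyl in place of hydrogen on an amine nitrogen in a ring. That step bears directly on the present one, since the same ring nitrogen is again substituted, but the allyl group is far smaller than the 3-(piperidin-1-yl)propyl group that was lost between compound 1 and compound 2, so only part of that loss is expected to be recovered. A step of a 3.8-fold lower number from compound 2 to compound 3 (0.57 log units; beyond the scatter) is therefore expected in this assay, clearly beyond the scatter. Compound 3 is thus estimated at 1.2 nM in this assay, with a range from 0.3 nM to 4.5 nM.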

Compound 3, inhibition constant: 1.63 nM
Estimate against measurement, compound 3: 1.4-fold (0.13 log units) below, within the range that was stated.
By their numbers in this assay, from the lowest: compound 1; then compound 3; then compound 2.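

Allyl on the ring nitrogen, a group of 3 carbon atoms with no hydrogen-bond donors or acceptors, still lowers the number in this assay, with a 2.8-fold lower number from compound 2 to compound 3 (0.44 log units; beyond the scatter), so a substituent at this nitrogen need not carry a piperidine for some affinity to return. It recovers only part of the affinity, however, since replacing the 3-(piperidin-1-yl)propyl group with allyl leaves a 15-fold higher number from compound 1 to compound 3 (1.19 log units; beyond the scatter), and most of what that longer group contributes remains unmatched. The data at hand offer no independent evidence that would account for either step.

The compounds shown leave open whether the remaining gap follows the length of the chain or its terminal piperidine. A plain propyl or longer alkyl chain, or a propyl chain ending in a dimethylamine or a hydroxyl group, would separate the two.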